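The source may hold more compounds than are shown below. What is called first, only, known or untested is meant among the compounds shown, and "the series" means these compounds.

In a functional assay, read by spectrophotometry, with a stated time of 5 min (on this read-out higher numbers stand for weaker inhibition and lower numbers for stronger inhibition), three compounds of one core have been measured. Compound 1 (`CCOc1cc(/C=C/C(=O)C(=Cc2ccc(O)c(OC)c2)C(=O)/C=C/c2ccc(O)c(OCC)c2)ccc1O`) stands at 5360 nM and compound 2 (`CCOc1cc(C=C(C(=O)/C=C/c2ccc(O)c(OCC)c2)C(=O)/C=C/c2ccc(O)c(OCC)c2)ccc1O`) at 5140 nM and the step between them, a 1.0-fold lower number from compound 1 to compound 2 (0.02 log units; within the scatter), does not separate them. Compound 3 (`CCOc1cc(/C=C/C(=O)C(=Cc2ccc(O)cc2)C(=O)/C=C/c2ccc(O)c(OCC)c2)ccc1O`) at 14800 nM has the highest number of the three and so is the weakest inhibitor among them. Compound 4 (`CCOc1cc(/C=C/C(=O)C(=Cc2ccc(O)c(O)c2)C(=O)/C=C/c2ccc(O)c(OCC)c2)ccc1O`) differs from compound 3 by hydroxy in place of hydrogen on an aromatic carbon, ortho to a hydroxy group, turning 4-hydroxyphenyl into 3,4-dihydroxyphenyl. Among the measured compounds shown here, two measured steps bear on this, each putting hydrogen in place of an oxygen-linked group on an aromatic carbon: a 2.8-fold higher number from compound 1 to compound 3 (0.44 log units; beyond the scatter) for methoxy and a 2.9-fold higher number from compound 2 to compound 3 (0.46 log units; beyond the scatter) for ethoxy, both modest and beyond the scatter. Read in reverse, they suggest that a group of this kind lowers the number, though no hydroxy compound has yet been measured. The expected change is a modest one toward stronger inhibition, estimated as a 3.0-fold lower number from compound 3 to compound 4 (0.47 log units; beyond the scatter) in this assay. Compound 4 is estimated at 5000 nM with an expected range from 2000 nM to 12000 nM for this measurement.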

Compound 4, half-maximal inhibitory concentration: 3630 nM
Beside the measured number, compound 4's estimate is 1.4-fold (0.14 log units) above it; low and high end bracket the measured number.
By their numbers in this assay, from the lowest: compounds 4, 2 and 1 (each within the scatter of the next); then compound 3.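

In this assay, adding a free hydroxy ortho to a hydroxy group gives a 4.1-fold lower number from compound 3 to compound 4 (0.61 log units; beyond the scatter) and so shows that an oxygen on this carbon needs no alkyl chain for the number to fall. The alkyl chain itself makes no readable difference here: both a 1.4-fold lower number from compound 2 to compound 4 (0.15 log units; within the scatter) and a 1.5-fold lower number from compound 1 to compound 4 (0.17 log units; within the scatter) leave hydroxy, ethoxy and methoxy at this position indistinguishable. Nothing available explains why the added oxygen matters.

Whether the oxygen itself is needed remains open, since the compounds shown do not include an amine or a fluorine on this carbon. Going by these compounds, it is also open whether a longer chain such as propoxy or butoxy would keep the number at this level.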